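Propargyl against propyl on the sulfur of the trimethoxybenzylidene member

The compounds below may be only part of what the source reports. "The series", "measured", "known", "first", "only" and "open" are said of these compounds alone.

Measured so far in a functional assay on ECa-109 cells (Homo sapiens) for antiproliferative activity, read by MTT assay, with a stated time of 72 h; a lower number here means a stronger inhibitor, a higher number a weaker inhibitor:
- compound 1 `CCCSc1nc(N/N=C/c2ccc(C)cc2)c2nnn(Cc3ccccc3)c2n1` gives > 64000 nM, which is a limit of this assay.
- compound 2 `C#CCSc1nc(N/N=C/c2cc(OC)c(OC)c(OC)c2)c2nnn(Cc3ccccc3)c2n1` gives 6540 nM.
- compound 3 `CCCSc1nc(N/N=C/c2cccc(Cl)c2)c2nnn(Cc3ccccc3)c2n1` gives > 64000 nM, which is a limit of this assay.

Within the data shown here, compound 2 holds the only number in this assay; the other two values are limits. Among the measured compounds shown here, the one step between measured compounds, a step that the two limits leave unreadable from compound 1 to compound 3, cannot be read at all, since both ends sit at the limit of > 64000 nM in this assay, at which 2 of the 3 values shown sit. Compound 4 `CCCSc1nc(N/N=C/c2cc(OC)c(OC)c(OC)c2)c2nnn(Cc3ccccc3)c2n1` keeps the trimethoxybenzylidene hydrazone and the benzyl-bearing core of compound 2 and differs only by ethyl in place of ethynyl on a saturated chain carbon bound to a sulfur. For the measured compounds named here, no measured step bears on this change directly: the two propyl members carry other benzylidene groups, and both are limits. The expectation therefore rests on compound 2 alone, with the change treated as small; a step of a 1.8-fold higher number from compound 2 to compound 4 (0.26 log units; within the scatter) in this assay is expected, toward the weaker side but with wide uncertainty. Compound 4 is estimated at 12000 nM, between 3000 nM and 50000 nM.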

Compound 4, half-maximal inhibitory concentration: 4060 nM
Compound 4: middle estimate off by 3.0-fold (0.47 log units), on the high side; low and high end bracket the measured number.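

In this assay, propylsulfanyl in place of propargylsulfanyl on the trimethoxybenzylidene member gives a 1.6-fold lower number from compound 2 to compound 4 (0.21 log units; within the scatter), so the two chains cannot be told apart at this position. With the trimethoxybenzylidene hydrazone and the benzyl-bearing core kept, the triple bond outside aromatic rings is therefore not needed for a measurable number. Compound 4 is also the only propyl member shown with a number, 4060 nM, so the propylsulfanyl chain does not by itself rule out a measurable number.

As far as these compounds go, the step between compound 1 and compound 3 cannot be read, and what the benzylidene group contributes among the propyl members stays open, because both of those values are limits: the limit of > 64000 nM in this assay, at which 2 of the 4 values shown sit. Whether a longer chain such as hexyl, or a carboxylic acid at the end of the chain, would keep the number in this assay also stays open.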